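The compounds below may be only part of what the source reports. "The series", "measured", "known", "first", "only" and "open" are said of these compounds alone.

Of the compounds shown here, three have been measured in a functional assay on A549 cells (Homo sapiens) for inhibition, read by sulforhodamine B assay, with a stated time of 48 h, tested at 50 uM; on this read-out lower numbers stand for less inhibition of growth and higher numbers for more inhibition of growth at the one concentration tested. Compound 1 `COc1ccc([C@@H]2C/C(=N/OCc3cn(-c4ccc(O)cc4)nn3)c3cc(CC=C(C)C)c(OC)cc3O2)cc1` gives 52%, compound 2 `COc1cc2c(cc1CC=C(C)C)/C(=N/NC(N)=O)C[C@@H](c1ccc(O)cc1)O2` gives 77%, and compound 3 `CCOc1ccc([C@@H]2CC(=O)c3cc(CC=C(C)C)c(OC)cc3O2)cc1` gives 37%. Among these three numbers compound 1 stands second highest: its reading lies beyond the usual scatter above that of compound 3 and beyond the usual scatter below that of compound 2, so at the single concentration tested it inhibits growth more than compound 3 and less than compound 2. No two of these measured compounds differ in only one place, so no single structural change can yet be tied to a change in the readings.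

Compound 4 `COc1ccc([C@@H]2C/C(=N/OCc3cn(-c4cccnc4Cl)nn3)c3cc(CC=C(C)C)c(OC)cc3O2)cc1` has not been measured. It shares the core of compound 1 and differs from it in one place: 2-chloropyridin-3-yl in place of 4-hydroxyphenyl on an aromatic nitrogen. Going by the values given here, none of the measured compounds shows what this exchange does to growth inhibition, so the expectation rests on compound 1 alone, whose reading is 52%. In this assay the expected step is a number 2 percentage points lower from compound 1 to compound 4 (within the scatter), a change not expected to reach beyond the usual scatter in either direction. Compound 4 is therefore estimated at 50%, with a range from 30% to 70%.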

Compound 4, percent growth inhibition at one concentration: 58%
Beside the measured number, compound 4's estimate is 8 percentage points below it, within the range that was stated.
By their numbers in this assay, from the lowest: compound 3; then compounds 1 and 4 (each within the scatter of the next); then compound 2.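

In this assay, going by these compounds alone, the first step that can be read at this position, 2-chloropyridin-3-yl in place of 4-hydroxyphenyl on an aromatic nitrogen of the five-membered ring, is a number 6 percentage points higher from compound 1 to compound 4 (within the scatter) and so gives no measurable change in growth inhibition at the one concentration tested. The exchange removes the only hydrogen-bond donor of this group and brings in a ring nitrogen and a chlorine, and the reading still does not move beyond the usual scatter, so for this pair the hydroxyl group is not needed to keep the reading where it stands. Nothing measured here explains why the reading holds across so large an exchange of atoms.

Going by these compounds, the exchange alters several things at once, so it remains open whether each alteration alone would also leave the reading in place, as a plain phenyl group or a pyridine ring without chlorine could show. On these data alone, it is equally open whether a group of a different kind at this place, such as a carboxylic acid, an amine or a short alkyl chain, would shift the reading beyond the scatter in either direction.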